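Methoxy in place of nitro on an aromatic carbon

A few compounds are considered here, and "the series" means these few. Any claim that something is new, unique, unknown or untested is made for them only; others in the source may bear on it.

Of the compounds shown here, three sharing one core have been measured in an ADME assay on cells (Peritoneal macrophage, Mus musculus, strain Balb/c) for cytotoxicity, read by resazurin assay, with a stated time of 72 h (on this read-out higher numbers stand for lower toxicity in this test and lower numbers for higher toxicity in this test), so far. There compound 1 (`CC1(Cc2cccc(/C(N)=N/O)c2)CC(S(=O)(=O)c2ccc(F)cc2)=C(c2ccc(/C(N)=N/O)cc2)O1`) gives 50200 nM, compound 2 (`CC1(Cc2ccc(C(F)(F)F)cc2)CC(S(=O)(=O)c2ccc(F)cc2)=C(c2ccc(/C(N)=N/O)cc2)O1`) gives 103000 nM and compound 3 (`CC1(Cc2ccc([N+](=O)[O-])cc2)CC(S(=O)(=O)c2ccc(F)cc2)=C(c2ccc(/C(N)=N/O)cc2)O1`) gives 97400 nM on the same scale. The value of compound 3 is not separated from either of the others (a 1.1-fold lower number from compound 2 to compound 3 (0.02 log units; within the scatter) and a 1.9-fold higher number from compound 1 to compound 3 (0.29 log units; within the scatter)). The only gap beyond the scatter is modest (a 2.1-fold higher number from compound 1 to compound 2 (0.31 log units; beyond the scatter)).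

Compound 4 (`COc1ccc(CC2(C)CC(S(=O)(=O)c3ccc(F)cc3)=C(c3ccc(/C(N)=N/O)cc3)O2)cc1`) carries one change (methoxy in place of nitro on an aromatic carbon), methoxy in place of nitro on an aromatic carbon, para to a large group. Among the compounds with values here, no measured compound has methoxy there, so the evidence is indirect. Within the data shown here, the one exchange measured at this carbon barely moved the number (a 1.1-fold lower number from compound 2 to compound 3 (0.02 log units; within the scatter)), and the wider group changes were small as well. The step expected in this assay is estimated as a 1.1-fold lower number from compound 3 to compound 4 (0.06 log units; within the scatter) and nothing beyond the scatter is expected in either direction. For compound 4 the estimate is 85000 nM with an expected range of 40000 nM to 180000 nM on that measure.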

Compound 4, half-maximal cytotoxic concentration: > 100000 nM
Compound 4 was reported as a limit; the forecaster's own chance of this, stated with the estimate: 10%; middle value at least 1.1-fold (0.07 log units) from the limit.
By their numbers in this assay, from the lowest: compounds 1, 3 and 2 (each within the scatter of the next, the first and the last beyond it).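

In this assay, within the data shown here, compound 4 is reported only as a limit, the only one among the values shown: the limit of > 100000 nM in this assay, at which 1 of the 4 values shown sits. The earlier exchange at this carbon, para to a large group, compared only nitro and trifluoromethyl, and methoxy now extends that series to a smaller group without giving any sign of a lower number. The floors of the readable steps both lie within the scatter (an at least 1.0-fold higher number from compound 3 to compound 4 (0.01 log units; that floor lies within the scatter)) (an at least 1.9-fold higher number from compound 1 to compound 4 (0.29 log units; that floor lies within the scatter)), and the step between compound 2 and compound 4 cannot be read.

The limit leaves open how far the true number of compound 4 lies from those of compound 2 and compound 3. The compounds shown also leave open whether an amine, a carboxylic acid or a longer chain such as ethoxy at this carbon would give a comparable number.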